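A few compounds are considered here, and "the series" means these few. Any claim that something is new, unique, unknown or untested is made for them only; others in the source may bear on it.

Measured compounds:
compound 1 `O=S(=O)(CC1=NCCS1)c1n[nH]cc1-c1ccccc1`, "not active" (no number reported)
compound 2 `O=S(=O)(CC1=NCCO1)c1c(-c2ccc(Cl)cc2)noc1-c1ccc(Cl)cc1`, "not active" (no number reported)
compound 3 `O=S(=O)(CC1=NCCO1)c1n[nH]cc1-c1ccccc1`, 54.7%

For the measured compounds named here, in a functional assay, read by Griess assay, with a stated time of 150 min, tested at 75 ug/mL (on this read-out lower numbers stand for a weaker effect and higher numbers for a stronger effect at the one concentration tested), compound 3 gives 54.7%, and this is the only number that the set shows. Going by the values given here, compound 1 is reported in this assay as "not active" (no number reported), and compound 2 likewise as "not active" (no number reported), each without a figure, so compound 3 stands alone as the one compound with a measured activity. Among the compounds with values here, no step between two measured compounds can be read from these entries, since the two other compounds carry no number.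

Compound 4 `O=S(=O)(CC1=NCCO1)c1n[nH]cc1-c1ccc(Cl)cc1` is the next compound to be tested in this assay. It differs from compound 3 in one place: chloro in place of hydrogen on an aromatic carbon. Within the data shown here, with only one numbered compound at hand there is no measured step on which to rest a firm direction, so the expectation is a modest change, not clearly beyond the usual scatter, with the step expected to be a number 9.7 percentage points lower from compound 3 to compound 4 (within the scatter). For compound 4 the estimated activity in this assay is 45%, expected to lie between 15% and 75%.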

Compound 4, a percentage reported as activity, at one concentration (the size of the read-out at that concentration, not a potency): "not active" (no number reported)
Compound 4 has no reported number here; the estimate stays without a comparison.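

In this assay, for the compounds shown here, compound 4 is reported as "not active" (no number reported) and so carries no figure to set against compound 3, and no step between the two can be read. Nothing shown here explains this result. The compounds shown leave open which changes to the phenyl group of compound 3 would keep a measurable activity in this assay.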